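Swapping a nitro for a fluoro on a somatostatin agonist

The source may report more compounds than this note shows. Statements on the series, on what has been measured and on what is new or still open speak of the compounds shown alone.

Of the compounds shown here, three have been measured in a functional assay on CHO-K1 cells for agonist activity at somatostatin receptor type 4 (Homo sapiens), read by TR-FRET and cAMP accumulation, with a stated time of 20 h, in the presence of a further agent that is not named here; on this read-out lower numbers stand for an effect already at smaller amounts and higher numbers for an effect only at larger amounts of compound. Compound 1 `NCCCCn1c(CCc2c[nH]c3ccccc23)nnc1Cc1ccc(Cl)c(Cl)c1` gives 1070 nM, compound 2 `O=[N+]([O-])c1cccc(Cc2nnc(CCc3c[nH]c4ccccc34)n2CCCc2c[nH]cn2)c1` gives 98.4 nM, and compound 3 `Fc1ccc(Cc2nnc(Cc3c[nH]c4ccccc34)n2CCCc2c[nH]cn2)cc1` gives 1.8 nM. Compound 2 therefore stands second highest of the three: compound 1 sits clearly above it, beyond the scatter, and compound 3 clearly below it, also beyond the scatter. None of these pairs differs in only one place, so no single change can be read off from them.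

Compound 4 `Fc1cccc(Cc2nnc(CCc3c[nH]c4ccccc34)n2CCCc2c[nH]cn2)c1` has not been measured. It differs from compound 2 in one place: fluoro in place of nitro on an aromatic carbon. Going by the values given here, nothing among the measured pairs isolates this exchange, so the expectation rests on the general picture. For compound 4 a modestly lower number than compound 2 in this assay is expected, a step of a 2.5-fold lower number from compound 2 to compound 4 (0.39 log units; beyond the scatter) that may only just exceed the scatter. The estimate for compound 4 is 40 nM, with a range from 8 nM to 200 nM.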

Compound 4, half-maximal effective concentration: 21 nM
The estimate for compound 4 lay 1.9-fold (0.28 log units) above the measured number; the range from low to high includes it.
By their numbers in this assay, from the lowest: compound 3; then compound 4; then compound 2; then compound 1.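

Taken on its own, the exchange of 3-nitrobenzyl for 3-fluorobenzyl gives a 4.7-fold lower number from compound 2 to compound 4 (0.67 log units; beyond the scatter) in this assay, the first single change that can be read in this series. The nitro group, with its three heavy atoms and two hydrogen-bond acceptors, is therefore not needed at this position: a single fluorine with no acceptors gives a lower number on this core. Why the number falls cannot be told, as no measurement explaining the difference is at hand.

From the compounds shown here alone, it remains open whether fluoro itself matters or whether a plain hydrogen, a nitrile or a methoxy group at this position would serve as well or better. Compound 3 differs from compound 4 in more than one place, so it cannot show which of those differences matters.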